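The compounds below may be only part of what the source reports. "The series", "measured", "known", "first", "only" and "open" are said of these compounds alone.

Measured so far:
Compound 1 `CCCCCCCCc1cc(-c2cn([C@H]3C[C@H](O)[C@@H](CO)O3)c(=O)[nH]c2=O)on1` gives 96.7% in a functional assay on MDA-MB-231 cells (Homo sapiens) for cytotoxicity, read by sulforhodamine B assay, tested at 10 uM; on this read-out lower numbers stand for less inhibition and higher numbers for more inhibition at the one concentration tested (going by the name of the read-out).
Compound 2 `CC(=O)OC[C@H]1O[C@@H](n2cc(-c3cc(C)no3)c(=O)[nH]c2=O)C[C@@H]1OC(C)=O` gives 106% in this assay.

Among these two numbers compound 2 stands highest, yet its nearest neighbour, compound 1, lies within the scatter of it, so the two cannot be told apart. Both share the same core and differ in the chain on the ring at one end and in the groups on the sugar at the other. Compound 3 `CCCCCc1cc(-c2cn([C@H]3C[C@H](OC(C)=O)[C@@H](COC(C)=O)O3)c(=O)[nH]c2=O)on1` has not yet been measured. Compared with compound 2 it carries butyl in place of hydrogen on a saturated chain carbon bound to an aromatic carbon. Going by the values given here, no measured pair differs in just this one place, so the size of such a step is unknown. Compound 1 carries a longer chain at the same place and gives 96.7%, while compound 2 gives 106%, the two within the scatter of each other. On this footing the step of a number 6 percentage points lower from compound 2 to compound 3 (within the scatter) in this assay is expected to be no larger than the scatter. Compound 3 is therefore estimated at 100% in this assay, within a range of 85% to 112%.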

Compound 3, a percentage reported as inhibition, at one concentration (the size of the read-out at that concentration, not a potency): 91.5%
Beside the measured number, compound 3's estimate is 8.5 percentage points above it, and the stated range covers the measured number.
By their numbers in this assay, from the lowest: compounds 3, 1 and 2 (each within the scatter of the next, the first and the last beyond it).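

In this assay, going by these compounds alone, replacing the methyl with a pentyl chain while leaving the rest of the molecule unchanged gives the first step that can be read at this position: a number 14.5 percentage points lower from compound 2 to compound 3 (beyond the scatter). The chain here therefore matters to this read-out, although the step is modest and compound 3 still gives 91.5%, so strong inhibition remains at the one concentration tested. Nothing available explains why the longer chain lowers the number.

As far as these compounds go, compound 1 carries a longer chain but also differs in its groups on the sugar, so the effect of chain length alone beyond pentyl remains unknown. One step also sets no trend, leaving open how an ethyl or propyl chain, or a chain ending in an amine or a carboxylic acid, would behave at this position.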